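A few compounds are considered here, and "the series" means these few. Any claim that something is new, unique, unknown or untested is made for them only; others in the source may bear on it.

Measured in a toxicity assay on cells (Macrophage, Homo sapiens) for inhibition, read by MTT assay; a higher number here means a weaker inhibitor, a lower number a stronger inhibitor:
- compound 1 `CN1CCN(CCCNc2nc(-c3ccc(F)cc3)nc3ccccc23)CC1`: 40000 nM
- compound 2 `COc1ccc(-c2nc(NCCN(C)C)c3ccccc3n2)cc1`: 57000 nM
- compound 3 `COc1ccc(-c2nc(NCCCN(C)C)c3ccccc3n2)cc1`: 67500 nM

All three values lie close together, and compound 3, at 67500 nM, stands within the usual scatter of both other compounds in this assay. The next compound, compound 4 `COc1ccc(-c2nc(NCCCN3CCN(C)CC3)c3ccccc3n2)cc1`, keeps the core and chain of compound 3 but carries 4-methylpiperazin-1-yl in place of dimethylamino, on a saturated chain carbon, three bonds along the chain from a nitrogen on an aromatic ring: 4-methylpiperazin-1-yl in place of dimethylamino on a saturated chain carbon, three bonds along the chain from a nitrogen on an aromatic ring.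

For the measured compounds named here, only one measured step is available, a 1.2-fold higher number from compound 2 to compound 3 (0.07 log units; within the scatter), and it alters the chain, not the terminal group, so it bears on this change only indirectly. Closer evidence comes from compound 1, which also carries 4-methylpiperazin-1-yl, though it differs from compound 4 elsewhere. In this assay compound 1 gives 40000 nM. No step beyond the scatter is therefore expected. The expected change is a 1.4-fold lower number from compound 3 to compound 4 (0.13 log units; within the scatter). For compound 4 the estimated value is 50000 nM, with an expected range from 22000 nM to 100000 nM.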

Compound 4, half-maximal inhibitory concentration: 53000 nM
The estimate for compound 4 lay 1.1-fold (0.03 log units) below the measured number; the range from low to high includes it.
By their numbers in this assay, from the lowest: compounds 1, 4, 2 and 3 (each within the scatter of the next).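

In this assay, 4-methylpiperazin-1-yl in place of dimethylamino on this saturated chain carbon comes to a 1.3-fold lower number from compound 3 to compound 4 (0.11 log units; within the scatter), and the same ring-bearing group read against the shorter chain comes to a 1.1-fold lower number from compound 2 to compound 4 (0.03 log units; within the scatter), so among these compounds the larger group with its six-membered non-aromatic ring produces no step beyond the scatter. Methoxy in place of fluoro on an aromatic carbon, a change the earlier compounds could not isolate, comes to a 1.3-fold higher number from compound 1 to compound 4 (0.12 log units; within the scatter), which also stays within the scatter. Nothing available explains why these numbers stay so close together.

On these data alone, whether a morpholine ring, a primary amine or a carboxylic acid on this chain carbon would give a step beyond the scatter stays open. So does the effect of a longer chain, or of a hydroxy group in place of methoxy.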